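The source may report more compounds than this note shows. Statements on the series, on what has been measured and on what is new or still open speak of the compounds shown alone.

Measured so far in a functional assay on the whole organism (plasma) with Rattus norvegicus as the target; a higher number here means that more compound is needed for the effect, a lower number that less compound is needed:
- compound 1 `CSc1cc(C)nc(SC)c1NC(=O)N(Cc1ccccc1)Cc1cccc(-c2cc[nH]n2)c1`: 0.046 mg/kg
- compound 2 `CSc1cc(C)nc(SC)c1NC(=O)N(Cc1ccc(N(C)C)cc1)Cc1cccc(-c2cc[nH]n2)c1`: < 0.1 mg/kg

Compound 2 stands only at a limit of this assay, so it has a ceiling reported rather than a number: < 0.1 mg/kg.

Compound 3 `CSc1cc(C)nc(SC)c1NC(=O)N(Cc1ccc(F)cc1)Cc1cccc(-c2cc[nH]n2)c1` differs from compound 2 in one place, on an aromatic carbon of a six-membered aromatic ring of carbon only, para to a large group. There, fluoro takes the place of dimethylamino, turning 4-(dimethylamino)benzyl into 4-fluorobenzyl (fluoro in place of dimethylamino on an aromatic carbon).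

For the measured compounds named here, one measured step touches this place, where dimethylamino replaces hydrogen: a step that the limit leaves unreadable from compound 1 to compound 2. It therefore offers no size to carry over. The firmest anchor is compound 1, which has hydrogen at this place and gives 0.046 mg/kg, so the new compound is expected to fall near that number. No direction can be claimed with confidence, and the expected step is a step that the limit leaves unreadable from compound 2 to compound 3. For compound 3 the estimate is 0.05 mg/kg, with an expected range from 0.015 mg/kg to 0.15 mg/kg.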

Compound 3, dose for half-maximal effect: < 0.1 mg/kg
Compound 3: a limit, no number; the forecaster's own chance of this, stated with the estimate: 25%; the middle value does not contradict the limit.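

Compound 3 gives < 0.1 mg/kg in this assay, which is a limit and not a number. No step among compound 1, compound 2 and compound 3 can be read, because the comparison stops at this limit: the limit of < 0.1 mg/kg in this assay, at which 2 of the 3 values shown sit.

The compounds shown leave open whether fluoro or dimethylamino on the benzyl group changes the dose needed for the effect, and in which direction.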